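The compounds below may be only part of what the source reports. "The series", "measured", "known", "first", "only" and "open" are said of these compounds alone.

Compound 2 `CO[C@@]12CCN(Cc3ccccc3)C[C@H]1[C@H](c1ccc(Cl)cc1Cl)C(C#N)=C(N)O2` and compound 1 `CO[C@@]12CCN(Cc3ccccc3)C[C@H]1[C@H](c1ccc(Cl)cc1)C(C#N)=C(N)O2` share one core and differ only in a chloro group. In a functional assay on trachea (Cavia porcellus) (on this read-out higher numbers stand for weaker inhibition and lower numbers for stronger inhibition), compound 2 gives 18300 nM, while compound 1 gives 18500 nM; the two numbers sit within the scatter of each other, so neither can be called stronger. Compound 3 `CO[C@@]12CCN(Cc3ccccc3)C[C@H]1[C@H](c1ccc(F)cc1)C(C#N)=C(N)O2` is not yet measured in this assay. Its difference from compound 2 is 4-fluorophenyl in place of 2,4-dichlorophenyl on a saturated ring carbon. Among the compounds with values here, the only measured step that bears on this change is a 1.0-fold lower number from compound 1 to compound 2 (0.00 log units; within the scatter), which shows that adding or removing a chloro group on that aromatic ring made no difference beyond the scatter. Within the data shown here, no measured compound carries fluorine on this ring, so the effect of that exchange is unknown. The expectation is therefore a step of about a 1.1-fold higher number from compound 2 to compound 3 (0.04 log units; within the scatter), with no clear direction. Compound 3 is estimated at 20000 nM in this assay, with a range from 8000 nM to 50000 nM.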

Compound 3, half-maximal inhibitory concentration: 17200 nM
Estimate against measurement, compound 3: 1.2-fold (0.07 log units) above; measured number inside the range.
By their numbers in this assay, from the lowest: compounds 3, 2 and 1 (each within the scatter of the next).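

In this assay, the step of a 1.1-fold lower number from compound 1 to compound 3 (0.03 log units; within the scatter) exchanges fluoro for chloro on the aromatic ring, so one halogen is now swapped for another rather than a chloro group simply added, and the step stays within the scatter. The step of a 1.1-fold lower number from compound 2 to compound 3 (0.03 log units; within the scatter), which places 4-fluorophenyl where 2,4-dichlorophenyl stood on the saturated ring carbon, also stays within the scatter, so this read-out does not separate the three halogen-bearing phenyl groups. Nothing available explains this lack of separation.

The compounds shown leave open whether a phenyl ring with no halogen, or one carrying a methoxy or an amino group, would read differently at this position. They also leave open whether replacing the cyano group with a carboxylic acid would produce a step beyond the scatter.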